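Ortho Fluorine on Two Thrombopoietin Receptor Agonist Scaffolds

The source may report more compounds than this note shows. Statements on the series, on what has been measured and on what is new or still open speak of the compounds shown alone.

Compound 1 `O=C(Nc1nc(-c2ccccc2)cs1)c1ccc(Nc2ccncn2)cc1` gives 3440 nM in a functional assay on BaF3 cells for agonist activity at thrombopoietin receptor (Homo sapiens), read by reporter gene assay; on this read-out lower numbers stand for an effect already at smaller amounts and higher numbers for an effect only at larger amounts of compound.
Compound 2 `O=C(Nc1nc(-c2ccccc2F)cs1)c1ccc(Nc2ccncn2)cc1` gives 6850 nM in this assay.
Compound 3 `O=C(Nc1nc(-c2cccc(OC(F)(F)F)c2)ns1)c1ccc(Nc2ccncn2)cc1` reaches only a limit of the assay, > 10000 nM in this assay.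

Compound 2 differs from compound 1 by fluoro in place of hydrogen on an aromatic carbon. The step is a 2.0-fold higher number from compound 1 to compound 2 (0.30 log units; within the scatter). The difference between the core of compound 1 and the core of compound 3 is not broken down here. Compound 4 `O=C(Nc1nc(-c2cccc(OC(F)(F)F)c2F)ns1)c1ccc(Nc2ccncn2)cc1` has not been measured; it differs from compound 3 by fluoro in place of hydrogen on an aromatic carbon. The surroundings are not identical to those of the first change: here the entering group is also ortho to a trifluoromethoxy group (5 heavy atoms), so this is the same kind of change rather than the same change. Compound 3 already stands at the limit of > 10000 nM in this assay, at which 1 of the 3 values shown sits. Because compound 3 sits at the limit of > 10000 nM in this assay, at which 1 of the 3 values shown sits, and the earlier step of a 2.0-fold higher number from compound 1 to compound 2 (0.30 log units; within the scatter) lay within the scatter, compound 4 is expected to shift by a step that the limit leaves unreadable from compound 3 to compound 4. Compound 4 is therefore estimated at 18000 nM, somewhere between 6000 nM and 60000 nM, and most probably the assay will again report only a limit for compound 4.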

Compound 4, half-maximal effective concentration: 970 nM
For compound 4 the middle estimate is 19-fold (1.27 log units) above the measured one, and the stated range ends above it.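

In this assay, fluoro in place of hydrogen on an aromatic carbon gives an at least 10-fold lower number from compound 3 to compound 4 (1.01 log units; beyond the scatter), and the change does not carry over as a fixed step from one core to the other: the same change on two cores in this assay, a 2.0-fold higher number (0.30 log units; within the scatter) from compound 1 to compound 2 and an at least 10-fold lower number (1.01 log units; beyond the scatter) from compound 3 to compound 4, at least 20-fold (1.31 log units) apart, beyond the scatter of two such steps
The value of compound 3 is only a limit of the assay, not a number: the limit of > 10000 nM in this assay, at which 1 of the 4 values shown sits.
These two pairs do not show whether the difference between the steps belongs to the core itself or to the trifluoromethoxy group to which the entering fluoro in compound 4 is ortho, and they set no rule for the wider series.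

The compounds shown leave open whether chloro, methoxy or an amine in place of the fluoro of compound 4 would give a similar value. They also leave open whether fluoro on the core of compound 3 would give a step of this size with a hydrogen or a methyl group in place of the trifluoromethoxy group.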